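From ethylcarbamoyl to methylcarbamoyl on compound 2

The compounds below may be only part of what the source reports. "The series", "measured", "known", "first", "only" and "open" are said of these compounds alone.

Of the compounds shown here, three have so far been measured in a functional assay on NCI-H1975 cells (Homo sapiens) for antiproliferative activity, with a stated time of 72 h; a higher number here means a weaker inhibitor of growth, a lower number a stronger inhibitor of growth. Compound 1 (`COc1cc(CN(C)C(=O)c2cc(Cl)c(O)cc2O)c(Cl)c(OC)c1OC`) gives 33800 nM, and compound 3 (`Cc1ccccc1CN(C)C(=O)c1cc(Cl)c(O)cc1O`) gives 47500 nM. Compound 2 (`CCNC(=O)c1ccc(CN(C)C(=O)c2cc(C(C)C)c(O)cc2O)cc1`) gives 460 nM, the lowest number of the three. Its gaps to both of the others lie well beyond the usual scatter of repeated measurements, so compound 2 is the strongest inhibitor of growth in this small set. These gaps cannot be traced to any single group, since compound 2 differs from compound 1 and from compound 3 in more than one place.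

The next compound, compound 4 (`CNC(=O)c1ccc(CN(C)C(=O)c2cc(C(C)C)c(O)cc2O)cc1`), differs from compound 2 in just one place: hydrogen in place of methyl on a saturated chain carbon bound to an amide-type nitrogen. This puts hydrogen in place of methyl on a saturated chain carbon bound to an amide-type nitrogen, turning ethylcarbamoyl into methylcarbamoyl. Among the measured compounds shown here, no measured pair shows this change, so the expectation rests only on how small the edit is, starting from compound 2 at 460 nM. The expected step of a 1.1-fold higher number from compound 2 to compound 4 (0.04 log units; within the scatter) in this assay stays within the scatter, with neither direction favoured. For compound 4 the estimated value is 500 nM, with an expected range from 200 nM to 1200 nM.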

Compound 4, concentration for 50% growth inhibition: 860 nM
For compound 4 the middle estimate is 1.7-fold (0.24 log units) below the measured one, and the stated range covers the measured number.
By their numbers in this assay, from the lowest: compounds 2 and 4 (each within the scatter of the next); then compounds 1 and 3 (each within the scatter of the next).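

In this assay the swap of ethylcarbamoyl for methylcarbamoyl gives a 1.9-fold higher number from compound 2 to compound 4 (0.27 log units; within the scatter) and so leaves the two compounds indistinguishable by this read-out. Among the compounds shown here, this is the only pair so far that differs in one place, and it shows that hydrogen can stand in place of methyl on a saturated chain carbon bound to an amide-type nitrogen without opening a gap larger than the scatter of repeated measurements. No supporting data are available to explain this result.

The compounds shown leave open whether a longer chain such as propyl, a ring such as cyclopropyl, or an unsubstituted carboxamide at this place would also stay within the scatter of compound 2. They also leave open what a carboxylic acid or an amine would do in place of the whole ethylcarbamoyl group, and which of the several differences separating compound 2 from compound 1 and compound 3 accounts for the wide gaps to those two compounds.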